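Iodo for Isopropyl: What Compound 4 Should Show

This account rests on a few compounds, and the source may have more. Where it says the series, first, only, none or still open, it means among the compounds named here.

compound 1, `CC(C)C(=O)Nc1ccc(S(=O)(=O)Oc2ccccc2C(C)C)cc1`: 11000 nM
compound 2, `CC(C)C(=O)Nc1ccc(S(=O)(=O)Oc2ccccc2I)cc1`: 13000 nM
compound 3, `CC(C)c1ccccc1OS(=O)(=O)c1ccc(NC(=O)CCCl)cc1`: 14000 nM

These three values come from a functional assay on M21 cells (Homo sapiens) for antiproliferative activity, read by sulforhodamine B assay, with a stated time of 48 h; a lower number here means a stronger inhibitor, a higher number a weaker inhibitor. All three lie within the scatter of one another, so none is set apart from the rest.

Compound 4, `O=C(CCCl)Nc1ccc(S(=O)(=O)Oc2ccccc2I)cc1`, has not yet been measured in this assay. It differs from compound 3 by iodo in place of isopropyl on an aromatic carbon. The same change was made from compound 1 to compound 2, where it gave a 1.2-fold higher number from compound 1 to compound 2 (0.07 log units; within the scatter). The cores of compound 1 and compound 3 differ by 2-chloroethyl in place of isopropyl on a carbonyl carbon, a change that gave a 1.3-fold higher number from compound 1 to compound 3 (0.10 log units; within the scatter). Both places read alike, so the change to compound 4 is the same change, made on the other core.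

Since in this assay that change gave only a 1.2-fold higher number from compound 1 to compound 2 (0.07 log units; within the scatter), a step of like size is expected for compound 4, estimated as a 1.1-fold higher number from compound 3 to compound 4 (0.06 log units; within the scatter). The expected value for compound 4 in this assay is 16000 nM, with a range from 8000 nM to 32000 nM.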

Compound 4, half-maximal inhibitory concentration: 12000 nM
Compound 4: middle estimate off by 1.3-fold (0.12 log units), on the high side; the measured number falls inside the stated range.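

In this assay, iodo in place of isopropyl on an aromatic carbon gave a 1.2-fold lower number from compound 3 to compound 4 (0.07 log units; within the scatter), and the two readings of this change agree: the same change on two cores in this assay, a 1.2-fold higher number (0.07 log units; within the scatter) from compound 1 to compound 2 and a 1.2-fold lower number (0.07 log units; within the scatter) from compound 3 to compound 4, 1.4-fold (0.14 log units) apart, within the scatter of two such steps. Likewise, putting 2-chloroethyl in place of isopropyl on a carbonyl carbon gave a 1.1-fold lower number from compound 2 to compound 4 (0.03 log units; within the scatter), and these two readings agree too: the same change on two cores in this assay, a 1.3-fold higher number (0.10 log units; within the scatter) from compound 1 to compound 3 and a 1.1-fold lower number (0.03 log units; within the scatter) from compound 2 to compound 4, 1.4-fold (0.14 log units) apart, within the scatter of two such steps. This shows that neither change moved the number beyond the scatter on either core, but with steps this small it does not show that a real effect carries over, nor does it speak for any other core.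

The compounds shown leave open what an amine or a carboxylic acid would do in place of iodo on the aromatic carbon, and what a longer chain would do on the carbonyl carbon. On these data alone, whether any change at these two places can move the number beyond the scatter remains unknown.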